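Halophenyl for methoxyphenyl on the exocyclic arm

The source may hold more compounds than are shown below. What is called first, only, known or untested is meant among the compounds shown, and "the series" means these compounds.

Among the measured compounds shown here, compound 3 `C=CCn1c(=O)/c(=C\c2ccccc2OC)[nH]c(=O)/c1=C\c1ccccc1OC` carries 2-methoxyphenyl on the double-bonded chain carbon and stands at the weak end of the three numbers so far: in a functional assay on Huh-7 cells (Homo sapiens) for cytotoxicity, read by CCK-8 assay, with a stated time of 72 h (a higher number here means a weaker inhibitor, a lower number a stronger inhibitor), compound 3 gives 21200 nM, while compound 1 `C=CCn1c(=O)/c(=C\c2ccccc2Cl)[nH]c(=O)/c1=C\c1ccccc1OC` gives 6400 nM and compound 2 `C=CCn1c(=O)/c(=C\c2cccc(Cl)c2Cl)[nH]c(=O)/c1=C\c1ccccc1OC` gives 1200 nM. The two steps that end at compound 3 are a 3.3-fold higher number from compound 1 to compound 3 (0.52 log units; beyond the scatter) and an 18-fold higher number from compound 2 to compound 3 (1.25 log units; beyond the scatter), so replacing a chloro-bearing ring with the methoxy-bearing one has so far raised the number each time, and a 5.3-fold lower number from compound 1 to compound 2 (0.73 log units; beyond the scatter) shows that a second chloro lowers it further. Compound 4 `C=CCn1c(=O)/c(=C\c2ccc(F)c(Br)c2)[nH]c(=O)/c1=C\c1ccccc1OC` goes the other way: 3-bromo-4-fluorophenyl in place of 2-methoxyphenyl on a double-bonded chain carbon bound to an aromatic carbon. Both relevant steps point to a lower number for a ring carrying two halogens, though this ring carries them in a new pattern, so the size is uncertain. Compound 4 is expected to show a 7.1-fold lower number from compound 3 to compound 4 (0.85 log units; beyond the scatter) in this assay, landing near the range between compound 1 and compound 2. The estimate for compound 4 is 3000 nM, within 900 nM to 12000 nM.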

Compound 4, half-maximal inhibitory concentration: "not active" (no number reported)
For compound 4 the study gives words and no number, so the estimate cannot be set against anything.
By their numbers in this assay, from the lowest: compound 2; then compound 1; then compound 3.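

Among the compounds shown here, compound 4 is reported only in words, as "not active", in this assay, so no step linking it to compound 1, compound 2 or compound 3 can be read. No supporting data bear on this result. Going by these compounds, how 3-bromo-4-fluorophenyl ranks numerically against 2-methoxyphenyl and the chloro-bearing rings remains open.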